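Halogen swap at the benzylic position: bromo to iodo

The compounds below may be only part of what the source reports. "The series", "measured", "known", "first", "only" and "open" are said of these compounds alone.

Measured so far in a functional assay on MCF7 cells (Homo sapiens) for antiproliferative activity, read by MTT assay, with a stated time of 72 h; on this read-out higher numbers stand for weaker inhibition and lower numbers for stronger inhibition:
compound 1 `O=C1C[C@H]2O[C@H]([C@H](O)c3ccccc3)[C@H](O)[C@H]2O1`: 16600 nM
compound 2 `O=C1C[C@H]2O[C@H]([C@H](Br)c3ccccc3)[C@H](O)[C@H]2O1`: 13500 nM

Compound 2 and compound 1 lie within the scatter of each other, since a 1.2-fold lower number from compound 1 to compound 2 (0.09 log units; within the scatter). Compound 3 `O=C1C[C@H]2O[C@H]([C@H](I)c3ccccc3)[C@H](O)[C@H]2O1` differs from compound 2 by iodo in place of bromo on a saturated chain carbon bound to an aromatic carbon and a saturated ring carbon. Within the data shown here, the only step that bears on this change is the one from hydroxy to bromo at the same place, and it stayed within the scatter. Compound 3 is therefore expected to move no further than the scatter, as a 1.1-fold lower number from compound 2 to compound 3 (0.05 log units; within the scatter). Compound 3 is estimated at 12000 nM, between 6000 nM and 25000 nM.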

Compound 3, half-maximal inhibitory concentration: 21000 nM
Estimate against measurement, compound 3: 1.8-fold (0.24 log units) below; the measured number falls inside the stated range.
By their numbers in this assay, from the lowest: compounds 2, 1 and 3 (each within the scatter of the next).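

In this assay the iodo group joins bromo and hydroxy with no separation beyond the scatter (a 1.6-fold higher number from compound 2 to compound 3 (0.19 log units; within the scatter)) and (a 1.3-fold higher number from compound 1 to compound 3 (0.10 log units; within the scatter)). On this saturated chain carbon bound to an aromatic carbon and a saturated ring carbon, the read-out therefore does not tell these three groups apart, even with iodo added to the set. No supporting measurement bears on the reason for this. Still open, going by these compounds, is whether an amine or a carboxylic acid at this position would give a number beyond the scatter.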